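This account rests on a few compounds, and the source may have more. Where it says the series, first, only, none or still open, it means among the compounds named here.

In a functional assay on K562 cells (Homo sapiens) for cytotoxicity, read by MTT assay, with a stated time of 48 h (a lower number here means a stronger inhibitor, a higher number a weaker inhibitor), compound 1 `COc1cc(NC(=O)n2cc(-c3ccc(O)cc3)n(-c3cc(OC)c(OC)c(OC)c3)c2=O)cc(OC)c1OC` gives 10400 nM and compound 2 `COc1cc(-n2c(-c3ccc([N+](=O)[O-])cc3)cn(C(C)=O)c2=O)cc(OC)c1OC` gives 26600 nM. That makes compound 2 the weaker inhibitor of the two, by a gap beyond the usual scatter. Compound 3 `COc1ccc(-c2cn(C(C)=O)c(=O)n2-c2cc(OC)c(OC)c(OC)c2)cc1N` carries 3-amino-4-methoxyphenyl in place of 4-nitrophenyl on an aromatic carbon. For the measured compounds named here, no measured pair isolates this change, and compound 1 differs from compound 2 in more than one place, so it is only a loose guide. A large expected step toward stronger inhibition is still a reasonable guess, a 27-fold lower number from compound 2 to compound 3 (1.42 log units; beyond the scatter). Compound 3 is estimated at 1000 nM, with an expected range of 40 nM to 15000 nM.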

Compound 3, half-maximal inhibitory concentration: 500 nM
For compound 3 the middle estimate is 2.0-fold (0.30 log units) above the measured one, and the stated range covers the measured number.
By their numbers in this assay, from the lowest: compound 3; then compound 1; then compound 2.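

In this assay, replacing 4-nitrophenyl with 3-amino-4-methoxyphenyl on this aromatic carbon gives a 53-fold lower number from compound 2 to compound 3 (1.73 log units; beyond the scatter) in a single change. For the compounds shown here, this shows that the group at this carbon can strongly shift the number, which the earlier compounds could not isolate. Nothing available explains the size of this step. The change swaps a whole substituted ring, so the roles of the amino group, the methoxy group and the nitro group remain unseparated. A phenyl ring carrying only the amino group, or a carboxylic acid on that ring, would probe this further.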